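This account rests on a few compounds, and the source may have more. Where it says the series, first, only, none or still open, it means among the compounds named here.

Compound 1 `C/C(=C\CC/C(C)=C/CC[C@@H]1[C@@]2(C)CCC(=O)C(C)(C)[C@H]2CC[C@@]1(C)O)CC/C=C(\C)C(=O)OCc1cn(-c2ccccc2C)nn1`: > 150000 nM
Compound 2 `C/C(=C\CC/C(C)=C/CC[C@@H]1[C@@]2(C)CCC(=O)C(C)(C)[C@H]2CC[C@@]1(C)O)CC/C=C(\C)C(=O)OCc1cn(C[C@@H]2O[C@H](n3ccc(=O)[nH]c3=O)[C@H]3OC(C)(C)O[C@H]32)nn1`: 15300 nM

In a functional assay on A549 cells (Homo sapiens) for antiproliferative activity, read by MTT assay, with a stated time of 48 h (on this read-out lower numbers stand for stronger inhibition and higher numbers for weaker inhibition), compound 1 gives > 150000 nM, which is a limit of the assay and not a number; compound 1 thus stands at the limit of > 150000 nM in this assay, at which 1 of the 2 values shown sits. In this assay compound 2 gives 15300 nM. Compound 3 `C/C(=C\CC/C(C)=C/CC[C@@H]1[C@@]2(C)CCC(=O)C(C)(C)[C@H]2CC[C@@]1(C)O)CC/C=C(\C)C(=O)OCc1cn(-c2cccc(Cl)c2)nn1` differs from compound 1 in one place: 3-chlorophenyl in place of 2-methylphenyl on an aromatic nitrogen. For the measured compounds named here, no measured pair shows this change, and with only a limit for compound 1 the step is expected to be an at least 1.2-fold lower number from compound 1 to compound 3 (0.09 log units; that floor lies within the scatter), nothing beyond the usual scatter. Compound 3 is therefore estimated at 120000 nM, with a range from 40000 nM to 300000 nM.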

Compound 3, half-maximal inhibitory concentration: 147000 nM
The estimate for compound 3 lay 1.2-fold (0.09 log units) below the measured number; the range from low to high includes it.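

In this assay, 3-chlorophenyl in place of 2-methylphenyl on the aromatic nitrogen gives an at least 1.0-fold lower number from compound 1 to compound 3 (0.00 log units; that floor lies within the scatter). Compound 1 has only a limit of the assay, so the true size of this step cannot be read. Compound 3 shows that this exchange between two substituted phenyl groups, each of the same heavy-atom count, yields a value that stays close to that limit: the limit of > 150000 nM in this assay, at which 1 of the 3 values shown sits.

On these data alone, it remains open whether a phenyl carrying a carboxylic acid or an amine on this nitrogen would give a clearly lower number. The same question stands for a longer alkyl chain there.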